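From tert-Butoxy to tert-Butyl: A Small Expected Step

The source may hold more compounds than are shown below. What is called first, only, known or untested is meant among the compounds shown, and "the series" means these compounds.

For the measured compounds named here, in a functional assay on a cell-free system (plasma, Homo sapiens), with a stated time of 3 min (on this read-out lower numbers stand for stronger inhibition and higher numbers for weaker inhibition), compound 1 (`CC(C)(C)OC[C@@H](O)C(=O)N1[C@H](C(=O)NCc2cc(Cl)ccc2-n2cnnn2)C[C@@H]2C[C@@H]21`) gives 500 nM as its value, the lowest of the two numbers so far. Compound 2 (`CC(C)(C)[C@@H](O)C(=O)N1[C@@H]2C[C@@H]2C[C@H]1C(=O)NCc1cc(Cl)ccc1-n1cnnn1`) gives 1100 nM as its value, a gap beyond the usual scatter. Compound 3 (`CC(C)(C)C[C@@H](O)C(=O)N1[C@H](C(=O)NCc2cc(Cl)ccc2-n2cnnn2)C[C@@H]2C[C@@H]21`) is still unmeasured. It has tert-butyl in place of tert-butoxy on a saturated chain carbon, two bonds along the chain from a carbonyl carbon and an oxygen on a saturated carbon. Going by the values given here, no measured pair shows this swap alone, so any forecast is uncertain. Compound 2 also carries tert-butyl and still reaches 1100 nM as a measured number, so no step beyond the scatter is expected in this assay for this swap. The estimated step (a 1.2-fold higher number from compound 1 to compound 3 (0.08 log units; within the scatter)) is small and points towards slightly weaker inhibition. For compound 3 the estimate is 600 nM within an expected range from 200 nM to 1800 nM on this read-out.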

Compound 3, half-maximal inhibitory concentration: 570 nM
The estimate for compound 3 lay 1.1-fold (0.02 log units) above the measured number; low and high end bracket the measured number.
By their numbers in this assay, from the lowest: compounds 1, 3 and 2 (each within the scatter of the next, the first and the last beyond it).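

Replacing tert-butoxy with tert-butyl on this saturated chain carbon gives a 1.1-fold higher number from compound 1 to compound 3 (0.06 log units; within the scatter) in this assay, and this is the first pair shown that differs in this one place alone. The swap removes the oxygen of tert-butoxy along with its hydrogen-bond acceptor, yet this read-out does not separate the two compounds, so that oxygen is not needed here to keep the inhibition seen with compound 1. No measurement is available that would explain why the two groups read alike.

Both groups end in the same tert-butyl carbons, so the result says nothing about how an amine or a carboxylic acid would fare in this place. On these data alone, whether a longer chain, or a ring such as phenyl, would shift the number also remains open.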